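The source may report more compounds than this note shows. Statements on the series, on what has been measured and on what is new or still open speak of the compounds shown alone.

Compound 1 `O=[N+]([O-])c1ccc(CSc2nnc(-c3ccc4c(c3)OCCO4)n2-c2ccccc2)cc1`: 13800 nM
Compound 2 `Fc1ccccc1CSc1nnc(-c2ccc3c(c2)OCCO3)n1-c1ccccc1`: 810 nM

Within the data shown here, in a functional assay on HepG2 cells (Homo sapiens) for antiproliferative activity, read by MTT assay, with a stated time of 24 h (on this read-out lower numbers stand for stronger inhibition and higher numbers for weaker inhibition), compound 2 gives the lower of the two numbers; its only neighbour is compound 1, which differs by a 17-fold lower number from compound 1 to compound 2 (1.23 log units; beyond the scatter). Compound 3 `Fc1ccc(CSc2nnc(-c3ccc4c(c3)OCCO4)n2-c2ccccc2)c(F)c1` carries one further change: fluoro in place of hydrogen on an aromatic carbon, turning 2-fluorophenyl into 2,4-difluorophenyl. Among the measured compounds shown here, no measured step shows what a second fluoro on that ring does; the single measured step exchanged the whole aryl group and cannot be read across. The step is therefore expected to stay within the scatter, a 1.2-fold lower number from compound 2 to compound 3 (0.06 log units; within the scatter). Compound 3 is estimated at 700 nM, with a range from 250 nM to 2500 nM.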

Compound 3, half-maximal inhibitory concentration: 1960 nM
The estimate for compound 3 lay 2.8-fold (0.45 log units) below the measured number; the range from low to high includes it.
By their numbers in this assay, from the lowest: compound 2; then compound 3; then compound 1.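

In this assay, going from 2-fluorophenyl to 2,4-difluorophenyl weakens activity modestly (a 2.4-fold higher number from compound 2 to compound 3 (0.38 log units; beyond the scatter)), so adding a fluoro on this ring does not help here. Compound 3 still inhibits more strongly than the 4-nitrophenyl compound (a 7.0-fold lower number from compound 1 to compound 3 (0.85 log units; beyond the scatter)). No measurement offered here explains the loss.

Still open, on these data alone, is whether the weakening is specific to fluoro or would also follow from a chloro or methoxy group at the same ring carbon. It is also unclear how a 4-fluorophenyl group, with no 2-fluoro, would compare.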